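From a Bromophenyl Ether to a Dichlorophenyl Ether

The compounds below may be only part of what the source reports. "The series", "measured", "known", "first", "only" and "open" are said of these compounds alone.

Three compounds sharing one core were tested in a functional assay on HL-60 cells (Homo sapiens) for antiproliferative activity, read by MTT assay, with a stated time of 72 h; a higher number here means a weaker inhibitor, a lower number a stronger inhibitor. Compound 1 `COc1ccc(OCCCON2C(N)=NC(N)=NC23CCSCC3)cc1` gives 500 nM; compound 2 `NC1=NC2(CCSCC2)N(OCCCOc2ccccc2Cl)C(N)=N1` gives 390 nM; compound 3 `NC1=NC2(CCSCC2)N(OCCCOc2cccc(Br)c2)C(N)=N1` gives 200 nM. Compound 3 has the lowest of the three numbers, yet its margin over compound 2, a 2.0-fold lower number from compound 2 to compound 3 (0.29 log units; within the scatter), is within the scatter, and only a 2.5-fold lower number from compound 1 to compound 3 (0.40 log units; beyond the scatter) reaches beyond it. Compound 4 `NC1=NC2(CCSCC2)N(OCCCOc2ccc(Cl)c(Cl)c2)C(N)=N1` is not yet measured. It differs from compound 3 in one place: 3,4-dichlorophenyl in place of 3-bromophenyl on an oxygen on a saturated carbon. Two earlier steps bear on this change, both swaps of the aryl group on the same oxygen: a 1.3-fold lower number from compound 1 to compound 2 (0.11 log units; within the scatter) and a 2.0-fold lower number from compound 2 to compound 3 (0.29 log units; within the scatter), each within the scatter, with only a 2.5-fold lower number from compound 1 to compound 3 (0.40 log units; beyond the scatter) counted as modest. The halogenated aryl groups therefore sit close together in this assay. The expectation for compound 4 is a step of a 1.3-fold lower number from compound 3 to compound 4 (0.12 log units; within the scatter) that does not exceed the scatter. Compound 4 is estimated at 150 nM, within a range of 60 nM to 400 nM.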

Compound 4, half-maximal inhibitory concentration: 140 nM
For compound 4 the middle estimate is 1.1-fold (0.03 log units) above the measured one, and the stated range covers the measured number.
By their numbers in this assay, from the lowest: compounds 4, 3, 2 and 1 (each within the scatter of the next, the first and the last beyond it).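

In this assay, the change from 3-bromophenyl to 3,4-dichlorophenyl on this oxygen gives a 1.4-fold lower number from compound 3 to compound 4 (0.15 log units; within the scatter), so these two aryl groups cannot be told apart here. The new point lies in the comparison with 2-chlorophenyl: compound 3 did not clearly separate from it (a 2.0-fold lower number from compound 2 to compound 3 (0.29 log units; within the scatter)), whereas 3,4-dichlorophenyl does (a 2.8-fold lower number from compound 2 to compound 4 (0.44 log units; beyond the scatter)), and the step from 4-methoxyphenyl, a 3.6-fold lower number from compound 1 to compound 4 (0.55 log units; beyond the scatter), is the widest listed in this set, though still modest. Nothing at hand accounts for these differences.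

Going by these compounds, all four compounds keep the same chain and the shared core, so how a longer chain would read in this assay remains open. On these data alone, it is also open whether a pyridine ring, or an aryl ring bearing an amine or a carboxylic acid, would fit with the halogenated aryl groups at this position.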